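A Methyl Added to Compound 2

The compounds below may be only part of what the source reports. "The series", "measured", "known", "first", "only" and "open" are said of these compounds alone.

Measured so far in a functional assay on A549 cells (Homo sapiens) for cytotoxicity, read by MTT assay, with a stated time of 72 h; on this read-out higher numbers stand for weaker inhibition and lower numbers for stronger inhibition:
Compound 1 (`Cc1ccc(F)cc1NC(=O)CN1CCN(c2nnc(Cc3ccccc3)c3ccccc23)CC1`) gives "not active" (no number reported)
Compound 2 (`O=C(CN1CCN(c2nnc(Cc3ccncc3)c3ccccc23)CC1)Nc1cccc(F)c1`) gives 4600 nM

Among the measured compounds shown here, compound 2 carries the only number in this small set, since compound 1 was reported without one, so compound 2 cannot be ranked against a second value. Compound 3 (`Cc1ccc(F)cc1NC(=O)CN1CCN(c2nnc(Cc3ccncc3)c3ccccc23)CC1`) differs from compound 2 in one place: methyl in place of hydrogen on an aromatic carbon (methyl in place of hydrogen on an aromatic carbon, ortho to a large group and para to a fluoro group). The 3-fluorophenyl thus becomes 5-fluoro-2-methylphenyl. For the measured compounds named here, no measured pair shows the size of such a change in this assay, so only a small shift toward weaker inhibition is expected, perhaps none beyond the scatter. The estimated step of a 1.3-fold higher number from compound 2 to compound 3 (0.12 log units; within the scatter) is therefore modest, and the expectation rests on compound 2 at 4600 nM as its anchor. Compound 3 is estimated at 6000 nM (expected range 2000 nM to 18000 nM).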

Compound 3, half-maximal inhibitory concentration: 38900 nM
For compound 3 the middle estimate is 6.5-fold (0.81 log units) below the measured one, and the stated range ends below it.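

In this assay, among the compounds shown here, replacing the 3-fluorophenyl with 5-fluoro-2-methylphenyl gives an 8.5-fold higher number from compound 2 to compound 3 (0.93 log units; beyond the scatter), the first measured step. It shows that a single methyl in place of hydrogen on this aromatic carbon, ortho to a large group and para to a fluoro group, can go with clearly weaker inhibition, so this position is not indifferent to change on this read-out. Nothing measured here accounts for the size of the step, and its cause remains unknown.

The compounds shown leave open whether a smaller or larger group at this place, such as a chloro group or an ethyl, would give a step of similar size. They also leave open whether a methyl on another carbon of this ring would do the same.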